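A few compounds are considered here, and "the series" means these few. Any claim that something is new, unique, unknown or untested is made for them only; others in the source may bear on it.

Working notes on the series in an in vitro functional assay on HEK293-A cells for antagonist activity at metabotropic glutamate receptor 5 (Rattus norvegicus), read by fluorescence and calcium flux, with a stated time of 140 s; a higher number here means a weaker inhibitor, a lower number a stronger inhibitor. Compound 1 `Cc1nc2cc(-c3ccc(OCc4ccccc4)c(C#N)c3)ccc2s1` gives > 10000 nM in this assay, which is a limit of the assay and not a number. Among the measured compounds shown here, compound 3 `COCOc1ccc(-c2ccc3ccc(C)nc3c2)cc1C#N` gives 294 nM in this assay, the only numerical value so far. Compound 2 `N#Cc1cc(-c2ccc3scnc3c2)ccc1-c1cccnc1` is the starting point of the step followed here. In this assay compound 2 gives > 10000 nM, again a limit and not a number. Compound 2 thus stands at the limit of > 10000 nM in this assay, at which 2 of the 3 values shown sit, together with compound 1, and below anything that can be ranked against compound 3. For the measured compounds named here, no step between two measured compounds that differ in one place is available, so no measured step size guides the change considered next. Compound 4 `N#Cc1cc(-c2ccc3scnc3c2)ccc1-c1ccccc1` is not yet measured; its change from compound 2 is phenyl in place of pyridin-3-yl on an aromatic carbon. For this change the step in this assay is expected to stay within the scatter, with some chance of a move toward a stronger inhibitor. Compound 4 is expected to give about 8000 nM in this assay, with a range from 1000 nM to 30000 nM. This corresponds to an estimated step of an at least 1.2-fold lower number from compound 2 to compound 4 (0.09 log units; that floor lies within the scatter).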

Compound 4, half-maximal inhibitory concentration: 6890 nM
The estimate for compound 4 lay 1.2-fold (0.06 log units) above the measured number; measured number inside the range.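

In this assay, among the compounds shown here, phenyl in place of pyridin-3-yl, on an aromatic carbon ortho to a cyano group and para to a group of 9 heavy atoms, gives an at least 1.4-fold lower number from compound 2 to compound 4 (0.16 log units; that floor lies within the scatter) as the first step that can be read at all. Compound 4 gives 6890 nM and so supplies a number for this substitution site, where the pyridin-3-yl compound offers none. Compound 2 remains a limit of the assay and not a number, which leaves the step with a floor and no upper end: the limit of > 10000 nM in this assay, at which 2 of the 4 values shown sit.

With that floor inside the scatter, the compounds shown leave open whether the true difference between phenyl and pyridin-3-yl at this carbon lies within the scatter or well beyond it. Also open, going by these compounds, is how this position would read in this assay with a group of another kind on the same aromatic carbon, such as an amine or a carboxylic acid, and whether any such group would give a stronger inhibitor than the phenyl of compound 4.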